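Furan-3-yl to thiophen-3-yl exchange on the shared core

The source may report more compounds than this note shows. Statements on the series, on what has been measured and on what is new or still open speak of the compounds shown alone.

Compound 1 `O=c1[nH]cnc2c1c(-c1ccoc1)cn2[C@@H]1O[C@H](CO)[C@@H](O)[C@H]1O` is the weaker of the two measured compounds. In a functional assay on K562 cells (Homo sapiens), read by MTT assay, with a stated time of 72 h (on this read-out lower numbers stand for stronger inhibition and higher numbers for weaker inhibition), compound 1 gives 14500 nM, the highest number of the two; the nearest is compound 2 `C#Cc1cn([C@@H]2O[C@H](CO)[C@@H](O)[C@H]2O)c2ncnc(N(C)C)c12`, which in this assay gives 260 nM, a gap that lies beyond the scatter. Among the measured compounds shown here, compound 2 differs from compound 1 at more than one place, so its value only marks the spread of the series and no single step is drawn between the two.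

Compound 3 `O=c1[nH]cnc2c1c(-c1ccsc1)cn2[C@@H]1O[C@H](CO)[C@@H](O)[C@H]1O` differs from compound 1 in one place: thiophen-3-yl in place of furan-3-yl on an aromatic carbon. For the measured compounds named here, no measured pair shows how such an exchange of one five-membered aromatic ring for another plays out. In this assay the expected step is a 1.5-fold lower number from compound 1 to compound 3 (0.16 log units; within the scatter), toward a somewhat lower number but not clearly beyond the scatter. Compound 3 is estimated at 10000 nM, with a range of 4000 nM to 30000 nM.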

Compound 3, half-maximal inhibitory concentration: > 20000 nM
Compound 3: a limit, no number; the forecaster's own chance of this, stated with the estimate: 10%; middle value at least 2.0-fold (0.30 log units) away from the limit.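

In this assay compound 3 carries a limit of the assay, not a number: the limit of > 20000 nM in this assay, at which 1 of the 3 values shown sits.

Among the compounds shown here, this gives the first measured pair at this aromatic carbon, and the exchange can be read only as a floor: an at least 1.3-fold higher number from compound 1 to compound 3 (0.13 log units; that floor lies within the scatter). Thiophen-3-yl in place of furan-3-yl therefore brings no lower number at this position, even though the two groups match in heavy-atom count and in being a five-membered aromatic ring with 1 hetero atom.

Going by these compounds, how far the true number of compound 3 lies past its limit stays open, and with it whether the step goes beyond the scatter. Also open, on these data alone, is how a phenyl ring, an amine or a short alkyl chain at this aromatic carbon would read in this assay on the shared core.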